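Para-substituted trifluoromethoxy analogue in a bis-phenol pyridine series

The source may report more compounds than this note shows. Statements on the series, on what has been measured and on what is new or still open speak of the compounds shown alone.

Measured so far:
compound 1, `Oc1cccc(-c2cc(-c3ccccc3C(F)(F)F)cc(-c3cccc(O)c3)n2)c1`, 8150 nM
compound 2, `Oc1cccc(-c2cc(-c3ccc(C(F)(F)F)cc3)cc(-c3cccc(O)c3)n2)c1`, > 50000 nM

For the measured compounds named here, compound 1 is the only member of the series with a numerical value in a functional assay on HCT-15 cells (Homo sapiens) for inhibition; a higher number here means a weaker inhibitor, a lower number a stronger inhibitor. For compound 2 the value in this assay is a limit of the assay, not a number, sitting at the limit of > 50000 nM in this assay, at which 1 of the 2 values shown sits. Going by the values given here, the one measured step, an at least 6.1-fold higher number from compound 1 to compound 2 (0.78 log units; beyond the scatter), moves into that limit. Compound 3, `Oc1cccc(-c2cc(-c3ccc(OC(F)(F)F)cc3)cc(-c3cccc(O)c3)n2)c1`, differs from compound 2 by trifluoromethoxy in place of trifluoromethyl on an aromatic carbon. Among the compounds with values here, no measured step covers this exchange, so the only bearing comes from compound 2 sitting at the limit and from the step from compound 1 into it. Compound 3 is expected to change by a number no higher from compound 2 to compound 3 (the limit leaves the size open), which is no step beyond the scatter. Compound 3 is therefore estimated at 50000 nM in this assay, with a range from 15000 nM to 200000 nM, and most likely reported only as a limit again.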

Compound 3, half-maximal inhibitory concentration: > 50000 nM
Compound 3: only a limit was reported; the forecaster's own chance of this, stated with the estimate: 70%; the middle value lies on the limit itself.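

No step can be read from compound 2 to compound 3 in this assay, because both compounds are reported only as limits: the limit of > 50000 nM in this assay, at which 2 of the 3 values shown sit.

The compounds shown leave open how trifluoromethoxy compares with trifluoromethyl in this assay, and whether either group allows any measurable inhibition.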